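A few compounds are considered here, and "the series" means these few. Any claim that something is new, unique, unknown or untested is made for them only; others in the source may bear on it.

In a functional assay on HOP-62 cells (Homo sapiens) for inhibition, read by sulforhodamine B assay, with a stated time of 48 h (a higher number here means that more compound is tolerated, a lower number that less compound is tolerated), compound 1 `COc1cc(-c2nn(-c3cccc(NC(=O)Nc4cc(C(F)(F)F)cc(C(F)(F)F)c4)c3)cc2-c2ccncc2)ccc1Cl` gives 2950 nM. Compound 2 `COc1cc(-c2nn(-c3cccc(NC(=O)c4cccc(C(F)(F)F)c4)c3)cc2-c2ccncc2)ccc1Cl` reaches only the limit > 50000 nM in this assay, a limit and not a number. Compound 3 `O=C(Nc1cccc(-n2cc(-c3ccncc3)c(-c3ccc(Cl)c(O)c3)n2)c1)Nc1ccc(Cl)c(Cl)c1` likewise stops at the limit > 32500 nM in this assay. Compound 2 therefore stands at a limit, and of the three values shown a second one is a limit as well, so only compound 1 provides a number. Compound 4 `COc1cc(-c2nn(-c3cccc(NC(=O)Nc4cccc(C(F)(F)F)c4)c3)cc2-c2ccncc2)ccc1Cl` differs from compound 2 by (3-(trifluoromethyl)phenyl)amino in place of 3-(trifluoromethyl)phenyl on a carbonyl carbon. Going by the values given here, no measured pair isolates this change, but compound 1, which also carries an amino group on its carbonyl carbon, gives a number where compound 2 shows only a limit. The expected step is downward, toward less compound tolerated: an at least 3.3-fold lower number from compound 2 to compound 4 (0.52 log units; beyond the scatter). Compound 4 is estimated at 15000 nM, between 3000 nM and 50000 nM.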

Compound 4, concentration lethal to 50% of the cells: > 50000 nM
Compound 4 gave a limit, no number; the forecaster's own chance of this, stated with the estimate: 35%; middle value at least 3.3-fold (0.52 log units) from the limit.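

In this assay compound 4 stands at a limit, as compound 2 does, so the step between them cannot be read: the limit of > 50000 nM in this assay, at which 2 of the 4 values shown sit. The (3-(trifluoromethyl)phenyl)amino group alone therefore yields no number here. Hydrogen in place of trifluoromethyl on an aromatic carbon gives an at least 16-fold higher number from compound 1 to compound 4 (1.22 log units; beyond the scatter), so the measured number goes with that second trifluoromethyl and not with the amino group alone.

From the compounds shown here alone, whether a nitrile or a methyl on that aromatic carbon would restore a number stays open. Going by these compounds, the values behind the limits also remain unknown.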